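The compounds below may be only part of what the source reports. "The series", "measured", "known", "first", "only" and "open" are said of these compounds alone.

Working notes on the series. In a functional assay on HL-60 cells (Homo sapiens) for antiproliferative activity, read by sulforhodamine B assay, with a stated time of 72 h (on this read-out higher numbers stand for weaker inhibition and lower numbers for stronger inhibition), compound 1 `N#Cc1ccc(NC(=S)N/N=C/c2ccc3ccccc3n2)cc1` gives 4660 nM. For the measured compounds named here, this is the only number in hand for this assay; the one other value recorded is a limit rather than a number. Compound 2 `NC(=S)N/N=C/c1ccc2cccnc2n1` returns only a limit, > 100000 nM, in this assay. the limit of > 100000 nM in this assay, at which 1 of the 2 values shown sits, is the line on which compound 2 sits. Going by the values given here, compound 1 therefore stands alone as a measured figure, and compound 2 shows only that it gave a limit; no step between the two is computed here.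

Compound 3 `Cc1ccccc1NC(=S)N/N=C/c1ccc2ccccc2n1` is the next candidate. It differs from compound 1 in one place: 2-methylphenyl in place of 4-cyanophenyl on an amide-type nitrogen. Among the compounds with values here, no measured pair covers a change of this kind, so no step can be read from the data and the direction is open. The working expectation is a modest loss, a 1.9-fold higher number from compound 1 to compound 3 (0.29 log units; within the scatter), somewhat beyond the usual scatter but not large. Compound 3 is expected to give 9000 nM, with a range from 2500 nM to 40000 nM.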

Compound 3, half-maximal inhibitory concentration: 73200 nM
Estimate against measurement, compound 3: 8.1-fold (0.91 log units) below; the whole stated range lies below it.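

In this assay, exchanging 4-cyanophenyl for 2-methylphenyl on the amide-type nitrogen gives a 16-fold higher number from compound 1 to compound 3 (1.20 log units; beyond the scatter), the first step available in the series and a sign that activity at this position depends strongly on the aromatic group it carries. The pair does not separate the two parts of the change: the nitrile leaves and the methyl enters in one exchange, so the step cannot be assigned to either, and no measured property is shown that would explain it. Compound 3 still returns a number, whereas compound 2 gives only a limit, which is not a number: the limit of > 100000 nM in this assay, at which 1 of the 3 values shown sits.

The compounds shown leave open how the number responds to a plain phenyl group on this nitrogen, which would help separate the loss of the nitrile from the arrival of the methyl, or to an amine or a carboxylic acid on the phenyl ring. As far as these compounds go, it also remains open whether a benzyl group, with its longer link to the ring, would be tolerated here, and whether the same exchange gives a step of this size on another core.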